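The source may hold more compounds than are shown below. What is called first, only, known or untested is meant among the compounds shown, and "the series" means these compounds.

Four compounds share one core and differ in the groups on the pyridine-like ring. Compound 1 `COc1ccc2[nH]c([S+]([O-])Cc3nccc(N4CCCCC4)c3Cl)nc2c1` gives 7.72 umol/kg in a functional assay on the whole organism (stomach) for inhibition, with Rattus norvegicus as the target; on this read-out higher numbers stand for an effect only at larger amounts of compound and lower numbers for an effect already at smaller amounts. Compound 2 `COc1ccc2[nH]c([S+]([O-])Cc3nccc(N(C)C)c3Cl)nc2c1` gives 0.38 umol/kg in this assay; the change dimethylamino in place of piperidin-1-yl on an aromatic carbon produced a 20-fold lower number from compound 1 to compound 2 (1.31 log units; beyond the scatter). Compound 3 `COc1ccc2[nH]c([S+]([O-])Cc3cc(N4CCCCC4)c(Br)cn3)nc2c1` gives 1.05 umol/kg in this assay; how the core of compound 3 differs from the core of compound 1 is not broken down here. Compound 4 `COc1ccc2[nH]c([S+]([O-])Cc3cc(N(C)C)c(Br)cn3)nc2c1` is not yet measured. It carries the change (dimethylamino in place of piperidin-1-yl on an aromatic carbon), which is the same kind of change as that from compound 1 to compound 2, not the same: here the changed carbon is ortho to a bromo group rather than ortho to a chloro group. Compound 4 is therefore expected to give 0.15 umol/kg, between 0.04 umol/kg and 0.6 umol/kg. The expected step of a 7.0-fold lower number from compound 3 to compound 4 (0.85 log units; beyond the scatter) rests on the measured step of a 20-fold lower number from compound 1 to compound 2 (1.31 log units; beyond the scatter), taken somewhat smaller since the surroundings differ.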

Compound 4, dose for half-maximal effect in the Rattus norvegicus assay: 1.75 umol/kg
Estimate against measurement, compound 4: 12-fold (1.07 log units) below; measured number above the stated range.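

In the Rattus norvegicus assay, dimethylamino in place of piperidin-1-yl gives a 1.7-fold higher number from compound 3 to compound 4 (0.22 log units; within the scatter), so the large step seen on the core of compound 1 does not carry over to the core of compound 3, and the two steps differ: the same change on two cores in the Rattus norvegicus assay, a 20-fold lower number (1.31 log units; beyond the scatter) from compound 1 to compound 2 and a 1.7-fold higher number (0.22 log units; within the scatter) from compound 3 to compound 4, 34-fold (1.53 log units) apart, beyond the scatter of two such steps. In a physicochemical assay for acid dissociation, compound 3 gives 5.4 and compound 4 gives 5.8, so the same change does separate this pair: the measured acid dissociation constant of compound 3, 5.4, and of compound 4, 5.8, a number 0.40 log units higher (beyond the scatter). This does not show that the shift accounts for the two steps differing, nor which difference between the two cores matters.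

The compounds shown leave open how other amines, such as pyrrolidin-1-yl or morpholin-4-yl, would behave at this place on each core. They also leave open whether a chloro group in place of the bromo group would alter the outcome on the core of compound 3.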